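Anilide substituent exchange on the shared core

This account rests on a few compounds, and the source may have more. Where it says the series, first, only, none or still open, it means among the compounds named here.

Among the compounds with values here, compound 2 `O=C(Nc1ccc(C(=O)N2CCOCC2)cc1)c1cn(Cc2c(F)cccc2F)c2ccc(=O)[nH]c2c1=O` gives 188 nM in an in vitro assay on Sf21 cells for inhibition of high affinity 3',5'-cyclic-AMP phosphodiesterase 7A (Homo sapiens), read by scintillation proximity assay, with a stated time of 30 min; a lower number here means a stronger inhibitor, a higher number a weaker inhibitor; this is the highest of the two numbers so far, the nearest being compound 1 `CC(=O)Nc1ccc(NC(=O)c2cn(Cc3c(F)cccc3F)c3ccc(=O)[nH]c3c2=O)cc1` with 24 nM. Within the data shown here, the only measured step bearing on the next change is a 7.8-fold higher number from compound 1 to compound 2 (0.89 log units; beyond the scatter), which puts the morpholinylcarbonyl group at the weaker end of that pair. Compound 3 `CSc1ccc(NC(=O)c2cn(Cc3c(F)cccc3F)c3ccc(=O)[nH]c3c2=O)cc1` carries the change (methylsulfanyl in place of (morpholin-4-yl)carbonyl on an aromatic carbon). Taking the morpholinylcarbonyl group away is the reverse of the measured step, and compound 3 thus returns to a single simple substituent on that aromatic carbon, as in compound 1. A step back toward the number of compound 1 is therefore expected, probably of comparable size, though with one pair to lean on its extent is uncertain. The expected step is a 4.7-fold lower number from compound 2 to compound 3 (0.67 log units; beyond the scatter). Compound 3 is estimated at 40 nM, with a range from 12 nM to 130 nM.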

Compound 3, half-maximal inhibitory concentration: 86 nM
Compound 3: the middle estimate sits 2.2-fold (0.33 log units) below what was measured; the measured number falls inside the stated range.
By their numbers in this assay, from the lowest: compound 1; then compound 3; then compound 2.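

Replacing the morpholinylcarbonyl group with methylsulfanyl gives a 2.2-fold lower number from compound 2 to compound 3 (0.34 log units; beyond the scatter) and so recovers only part of the loss seen with that group. Compound 3 still sits apart from the acetamido compound, with a 3.6-fold higher number from compound 1 to compound 3 (0.55 log units; beyond the scatter) for the exchange at the same aromatic carbon, so the two simple substituents are not interchangeable here, and this position now separates three groups in the order acetamido, methylsulfanyl, (morpholin-4-yl)carbonyl, from the lowest number to the highest. No measurement available here accounts for this order.

As far as these compounds go, it remains open where an amine, a carboxylic acid or a longer acylamino chain at this aromatic carbon would fall relative to these three. From the compounds shown here alone, whether the same order holds with another group in place of the shared core's other substituents also remains open.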